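This account rests on a few compounds, and the source may have more. Where it says the series, first, only, none or still open, it means among the compounds named here.

Compound 1 `CCCCNC(=O)/C=C/c1c(/C=C/c2ccc(OC)cc2)cc(OC)cc1OC` gives 1330 nM 
Compound 2 `C#CCNC(=O)/C=C/c1c(/C=C/c2ccc(OC)cc2)cc(OC)cc1OC` gives 4560 nM 
Compound 3 `COc1ccc(/C=C/c2cc(OC)cc(OC)c2/C=C/C(=O)Nc2cc(OC)c(OC)c(OC)c2)cc1` gives 7010 nM 

These values come from a functional assay on MCF7 cells (Homo sapiens) for inhibition, read by MTT assay, with a stated time of 48 h (on this read-out higher numbers stand for weaker inhibition and lower numbers for stronger inhibition), and compound 1 holds the lowest number of the three. The next structure is compound 4 `COc1ccc(/C=C/c2cc(OC)cc(OC)c2/C=C/C(=O)N2CCCCC2)cc1` which has not yet been measured. It carries piperidin-1-yl in place of butylamino on a carbonyl carbon and the hydrogen-bond donor of butylamino leaves with that change.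

Among the compounds with values here, two measured steps bear on this, since both also alter what sits on the amide-type nitrogen of compound 1. They are a 3.4-fold higher number from compound 1 to compound 2 (0.54 log units; beyond the scatter) and a 5.3-fold higher number from compound 1 to compound 3 (0.72 log units; beyond the scatter) and both go upward. Neither of them removes the amide hydrogen, so they offer only a loose guide. A modest rise is still expected in this assay with a 2.3-fold higher number from compound 1 to compound 4 (0.35 log units; beyond the scatter) as the estimated step for this change. For compound 4 the estimated value is 3000 nM with an expected range from 1000 nM to 9000 nM in this measurement.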

Compound 4, half-maximal inhibitory concentration: 6050 nM
Estimate against measurement, compound 4: 2.0-fold (0.30 log units) below, and the stated range covers the measured number.
By their numbers in this assay, from the lowest: compound 1; then compounds 2, 4 and 3 (each within the scatter of the next).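

In this assay, within the data shown here, this is the first change on the carbonyl carbon that removes the amide hydrogen, and it gives a 4.5-fold higher number from compound 1 to compound 4 (0.66 log units; beyond the scatter). Set against propargylamino, which keeps that hydrogen, piperidin-1-yl gives a 1.3-fold higher number from compound 2 to compound 4 (0.12 log units; within the scatter), so compounds with and without the amide hydrogen are not told apart in this pair, while butylamino in compound 1 remains alone at the low end of the four. Nothing measured here explains these differences.

On these data alone, the step from compound 1 to compound 4 removes the hydrogen and closes a ring in one change, so the share of each remains open. Butyl(methyl)amino, which lacks the amide hydrogen and has no ring, could separate the two, and a longer chain such as hexylamino would show whether the butyl result extends further.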